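The source may report more compounds than this note shows. Statements on the series, on what has been measured and on what is new or still open speak of the compounds shown alone.

In an ADME assay (liver, Mus musculus) for metabolic stability, using microsomes (a higher number here means that the compound lasts longer, a lower number that the compound disappears faster), compound 2 `CCc1nc2cc(Cl)ccn2c1C(=O)NCc1ccc(N2CCC(Cl)CC2)cc1` gives 0.0867 h and compound 3 `CCc1nc2cc(Cl)ccn2c1C(=O)NCc1ccc(N2CC3CCCCC3C2)cc1` gives 0.105 h, which is a 1.2-fold higher number from compound 2 to compound 3 (0.08 log units; within the scatter). Compound 1 `CCc1nc2cc(Cl)ccn2c1C(=O)NCc1ccc(-c2ccc[nH]2)cc1` gives 0.18 h, and the two steps away from it are a 2.1-fold lower number from compound 1 to compound 2 (0.32 log units; beyond the scatter) and a 1.7-fold lower number from compound 1 to compound 3 (0.23 log units; within the scatter). Compound 4 `CCc1nc2cc(Cl)ccn2c1C(=O)NCc1ccc(N2CCC(c3ccc(Cl)cc3)CC2)cc1` follows from compound 2 by 4-chlorophenyl in place of chloro on a saturated ring carbon, with 4-chlorophenyl in place of chloro on a saturated ring carbon. Going by the values given here, no measured step makes this exchange. Among the compounds with values here, the closest precedent is the swap between the two saturated groups in compound 2 and compound 3, and that step stays within the scatter. No change beyond the scatter is therefore expected in this assay. The expected step is a 1.0-fold higher number from compound 2 to compound 4 (0.02 log units; within the scatter). For compound 4 the estimated half-life is 0.09 h, with an expected range of 0.045 h to 0.18 h.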

Compound 4, half-life: 1.87 h
Beside the measured number, compound 4's estimate is 21-fold (1.32 log units) below it; measured number above the stated range.
By their numbers in this assay, from the lowest: compounds 2, 3 and 1 (each within the scatter of the next, the first and the last beyond it); then compound 4.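

The exchange of chloro for 4-chlorophenyl gives a 22-fold higher number from compound 2 to compound 4 (1.33 log units; beyond the scatter) in this assay and shows that a single change on the saturated ring carbon, three ring bonds from the ring nitrogen, can move this read-out strongly. The largest earlier step, a 2.1-fold lower number from compound 1 to compound 2 (0.32 log units; beyond the scatter) and made on an aromatic carbon, is far smaller. Nothing measured here accounts for the new step.

The compounds shown leave open whether the step follows the aromatic ring or its chlorine. Unsubstituted phenyl, cyclohexyl or 4-methoxyphenyl on the same carbon would separate these readings.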